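The source may hold more compounds than are shown below. What is called first, only, known or untested is meant among the compounds shown, and "the series" means these compounds.

Values so far in a functional assay on HeLa cells (Homo sapiens) for inhibition, read by CCK-8 assay, with a stated time of 72 h, tested at 8 uM (on this read-out higher numbers stand for more inhibition of growth at the one concentration tested and lower numbers for less inhibition of growth), are these
compound 1 `CCc1ccc(SCc2ccc(C(=O)Nc3ccccc3N)cc2)cc1` gives 71%
compound 2 `Nc1ccccc1NC(=O)c1ccc(CSc2ccc(Br)cc2)cc1` gives 38.2%
compound 3 `CC(C)(C)c1ccc(SCc2ccc(C(=O)Nc3ccccc3N)cc2)cc1` gives 40.2%

Compound 2 with 38.2% cannot be told apart from compound 3 and lies far under compound 1. Compound 4 `Cc1cc(C)cc(SCc2ccc(C(=O)Nc3ccccc3N)cc2)c1` differs from it by 3,5-dimethylphenyl in place of 4-bromophenyl on a sulfur and so has 3,5-dimethylphenyl in place of 4-bromophenyl on a sulfur. Going by the values given here, three measured steps bear on this change. Both a number 32.8 percentage points lower from compound 1 to compound 2 (beyond the scatter) and a number 30.8 percentage points lower from compound 1 to compound 3 (beyond the scatter) are large and beyond the scatter, so changes to this group can shift the number strongly, whereas a number 2 percentage points higher from compound 2 to compound 3 (within the scatter) stays within the scatter. The ethyl group of compound 1 alone goes with a high number, and the tert-butyl group of compound 3 goes against any simple rule that alkyl groups raise it. Among the compounds with values here, no measured compound carries the 3,5-dimethylphenyl group, so only a moderate rise is expected, with wide uncertainty. In this assay the expected step is a number 11.8 percentage points higher from compound 2 to compound 4 (beyond the scatter) as estimated here. The estimate for compound 4 is 50% with an expected range of 30% to 72% overall.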

Compound 4, percent growth inhibition at one concentration: 78.9%
Compound 4: the middle estimate sits 28.9 percentage points below what was measured, and the stated range ends below it.
By their numbers in this assay, from the lowest: compounds 2 and 3 (each within the scatter of the next); then compounds 1 and 4 (each within the scatter of the next).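

In this assay, putting 3,5-dimethylphenyl in place of 4-bromophenyl on a sulfur gives a number 40.7 percentage points higher from compound 2 to compound 4 (beyond the scatter), so this position can carry a group that restores a high number without an ethyl group. Putting 3,5-dimethylphenyl in place of 4-ethylphenyl gives a number 7.9 percentage points higher from compound 1 to compound 4 (within the scatter), which means that a high number is no longer tied to the ethyl group of compound 1 alone, although the tert-butyl group of compound 3 still goes against any rule that alkyl groups raise the number. Nothing available explains why these groups on the sulfur read so differently. From the compounds shown here alone, it remains open whether the count of methyl groups or their placing on the ring matters. Going by these compounds, how an unsubstituted phenyl group, or a phenyl group bearing a methoxy group or an amine, would read at this position also remains open.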